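One More Methoxy on a Potent Compound

The source may report more compounds than this note shows. Statements on the series, on what has been measured and on what is new or still open speak of the compounds shown alone.

For the measured compounds named here, in a functional assay on MOLT-4 cells (Homo sapiens) for antiproliferative activity, read by cell counting, with a stated time of 2 days (on this read-out lower numbers stand for stronger inhibition and higher numbers for weaker inhibition), compound 1 `COc1ccc(Nc2nc(N)c(C(=O)c3ccc(OC)c(OC)c3)s2)cc1` gives 37 nM, the lower of the two numbers so far, and compound 2 `COc1cccc(C(=O)c2sc(Nc3ccccc3)nc2N)c1` gives 1300 nM. The gap between these two numbers lies well beyond the scatter. Compound 1 also carries more methoxy groups than compound 2, but they differ in more than one place, so this is only a faint hint. Compound 3 `COc1ccc(Nc2nc(N)c(C(=O)c3cc(OC)c(OC)c(OC)c3)s2)cc1` alters compound 1 at a single site: methoxy in place of hydrogen on an aromatic carbon, with methoxy in place of hydrogen on an aromatic carbon. A modest shift towards stronger inhibition is expected in this assay, possibly none beyond the scatter: a 1.9-fold lower number from compound 1 to compound 3 (0.27 log units; within the scatter). The estimate for compound 3 is 20 nM, within an expected range of 5 nM to 90 nM.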

Compound 3, half-maximal inhibitory concentration: 480 nM
For compound 3 the middle estimate is 24-fold (1.38 log units) below the measured one; the whole stated range lies below it.
By their numbers in this assay, from the lowest: compound 1; then compound 3; then compound 2.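

In this assay the added methoxy gives a 13-fold higher number from compound 1 to compound 3 (1.11 log units; beyond the scatter) and so marks a clear loss of inhibition from one small change. This aromatic carbon, ortho to a methoxy group and meta to a large group, therefore does not accept every substituent, even one of only two heavy atoms. Nothing available explains the loss.

Still open, from the compounds shown here alone, is whether the effect belongs to methoxy alone. Fluorine or a hydroxyl group on this same carbon could stay close to compound 1 or fall as far as compound 3.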